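The compounds below may be only part of what the source reports. "The series", "measured", "known", "first", "only" and "open" are said of these compounds alone.

Measured so far:

Compound 1 `CSCc1ccc(Nc2ncc(Cc3c(F)cccc3F)o2)cc1` gives > 100000 nM in an ADME assay on MT2 cells (Homo sapiens) for cytotoxicity, read by MTT assay (a lower number here means that less compound is tolerated, a higher number that more compound is tolerated), which is a limit of the assay rather than a number.

Compound 2 `Fc1cccc(F)c1Cc1cnc(Nc2ccc(COc3ccncc3)cc2)o1` gives > 100000 nM in this assay, again a limit and not a number.

Both measured compounds therefore sit at the limit of > 100000 nM in this assay, at which 2 of the 2 values shown sit: in each case the cells tolerated the highest concentration tested, so the true value is only known to lie at or beyond that point. Compound 2 stands nowhere more precise than this. Among the compounds with values here, the one structural step that has been measured, a step that the two limits leave unreadable from compound 1 to compound 2, cannot be given a size since both of its compounds sit at the limit of > 100000 nM in this assay, at which 2 of the 2 values shown sit.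

Compound 3 `COCc1ccc(Nc2ncc(Cc3c(F)cccc3F)o2)cc1` differs from compound 2 by methyl in place of pyridin-4-yl on an oxygen on a saturated carbon. Within the data shown here, the only measured step that bears on this change is the unreadable one from compound 1 to compound 2, so there is no basis to expect a shift beyond the scatter in this assay in either direction. Compound 3 is expected to give 150000 nM in this assay, with a range from 60000 nM to 400000 nM. The expected step is a step that the limit leaves unreadable from compound 2 to compound 3, most likely reported once more only as a limit.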

Compound 3, half-maximal cytotoxic concentration: 32000 nM
Compound 3: the middle estimate sits 4.7-fold (0.67 log units) above what was measured; the whole stated range lies above it.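

Within the data shown here, replacing pyridin-4-yl with methyl on the oxygen gives an at least 3.1-fold lower number from compound 2 to compound 3 (0.49 log units; beyond the scatter) in this assay, the first readable step in this short series, and it shows that the group at this place can change how much compound the cells tolerate. Exchanging methylsulfanyl for methoxy on the saturated chain carbon bound to an aromatic carbon gives an at least 3.1-fold lower number from compound 1 to compound 3 (0.49 log units; beyond the scatter), so compound 3 is the one of these three that the cells tolerate least. Both sizes are only minimum sizes, and the step from compound 1 to compound 2 still cannot be read, because compound 1 and compound 2 each stop at a limit: the limit of > 100000 nM in this assay, at which 2 of the 3 values shown sit.

Among these compounds, with only methyl and pyridin-4-yl on this oxygen, and methylsulfanyl as the one comparison without the oxygen, it remains open whether the methyl ether itself lowers the number or whether pyridin-4-yl and methylsulfanyl simply happen to leave the cells unharmed. A longer chain such as ethyl or propyl, a phenyl ring in place of pyridin-4-yl, or an amine on the same saturated carbon would help to separate these readings.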